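The source may report more compounds than this note shows. Statements on the series, on what has been measured and on what is new or still open speak of the compounds shown alone.

The account follows the change from compound 1 `Nc1cccc(/C=C2\SC(=O)N(Cc3cccc(F)c3)C2=O)c1` to compound 4 `Nc1cccc(/C=C2\SC(=O)N(Cc3cccc(Cl)c3)C2=O)c1`. In a functional assay on HeLa cells (Homo sapiens) for cytotoxicity, read by cell counting, with a stated time of 4 days (a lower number here means a stronger inhibitor, a higher number a weaker inhibitor), compound 1 gives > 250000 nM, which is a limit of the assay and not a number. Compound 1 therefore stands at the limit of > 250000 nM in this assay, at which 1 of the 3 values shown sits. Compound 2 `Nc1ccc(/C=C2\SC(=O)N(Cc3cccc(F)c3)C2=O)cc1` gives 250000 nM in this assay, and the step of a number no higher from compound 1 to compound 2 (the limit leaves the size open) cannot be read in size. Among the measured compounds shown here, compound 3 `C=C(Br)C(=O)Nc1ccc(/C=C2\SC(=O)N(Cc3ccc(F)cc3)C2=O)cc1` gives 2000 nM in this assay; no single-point step joins it to compound 1 or compound 2, so its value stands on its own.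

The change to compound 4 is chloro in place of fluoro on an aromatic carbon. Taken one bond further out, it reads 3-fluorophenyl to 3-chlorophenyl. For the measured compounds named here, none of the measured steps touches a halogen exchange of this kind: the only step measured in one place moves the amino group, and its size is open. Going by the values given here, there is thus no measured step that bears on the expected size of the step in this assay, and no basis for expecting a move in either direction beyond the scatter.

The writer expects compound 4 to remain at the limit, an expected step of a number no higher from compound 1 to compound 4 (the limit leaves the size open). For compound 4 the estimate is 250000 nM, with a range from 80000 nM to 600000 nM.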

Compound 4, half-maximal inhibitory concentration: 250000 nM
For compound 4 middle estimate and measured number coincide at the digits printed, within the range that was stated.
By their numbers in this assay, from the lowest: compound 3; then compounds 2 and 4 (each within the scatter of the next).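

In this assay compound 1 gives > 250000 nM, which is a limit of the assay and not a number. With chloro on this aromatic carbon, compound 4 gives 250000 nM, so the 3-chlorophenyl compound supplies the first actual number for the 3-aminophenyl compounds shown, but the change reads only as a number no higher from compound 1 to compound 4 (the limit leaves the size open), and this step, like the earlier one, cannot be read in size. Among the compounds shown here, the first halogen exchange at this position therefore gives no measure of what chloro in place of fluoro does, and the reading rests on a limit: the limit of > 250000 nM in this assay, at which 1 of the 4 values shown sits.

The compounds shown leave open whether a bromo, a methyl or a trifluoromethyl on the same aromatic carbon would give a number clearly apart from that of compound 4. They also leave open what an acetyl group on the amine of compound 4 would do in this assay, with the chloro kept in place.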